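This account rests on a few compounds, and the source may have more. Where it says the series, first, only, none or still open, it means among the compounds named here.

Measured so far:
compound 1 `O=C(O)CC(Cc1nc2cc(F)ccc2[nH]1)c1ccc(Cl)cc1`: 0%
compound 2 `O=C(O)CC(Cc1nc2cc(C(F)(F)F)ccc2[nH]1)c1ccc(Cl)cc1`: 35%

In an assay on isolated protein for inhibition of protein kinase C zeta type (Homo sapiens), read by 33P incorporation, tested at 50 uM (a lower number here means a weaker effect, a higher number a stronger effect of the compound at the concentration tested), compound 1 gives 0%, the lowest of the two numbers; its nearest neighbour is compound 2, with a number 35 percentage points higher from compound 1 to compound 2 (beyond the scatter). Compound 3 `O=C(O)CC(Cc1nc2cc(F)c(F)cc2[nH]1)c1ccc(Cl)cc1` differs from compound 1 by fluoro in place of hydrogen on an aromatic carbon. Within the data shown here, the one measured step, trifluoromethyl in place of fluoro, does not cover this change, so no step bears on it directly, and the expectation is a modest rise at most, possibly none beyond the scatter. Compound 3 is therefore estimated at 10% (range 0% to 30%), a step of a number 10 percentage points higher from compound 1 to compound 3 (within the scatter).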

Compound 3, a percentage reported as inhibition, at one concentration (the size of the read-out at that concentration, not a potency): 15%
The estimate for compound 3 lay 5 percentage points below the measured number; measured number inside the range.
By their numbers in this assay, from the lowest: compound 1; then compound 3; then compound 2.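

In this assay, the earlier step concerned only the aromatic carbon carrying the fluoro group. This result shows that a second carbon of the same ring also responds to substitution: placing fluoro there, ortho to a fluoro group, gives a number 15 percentage points higher from compound 1 to compound 3 (beyond the scatter). No measurement shown here explains this rise.

From the compounds shown here alone, whether chloro or methoxy on this carbon would move the number further remains open. So does whether the new fluoro would give a similar rise without the original fluoro group on the ring.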